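Halogen change on the shared core of compound 2

A few compounds are considered here, and "the series" means these few. Any claim that something is new, unique, unknown or untested is made for them only; others in the source may bear on it.

Working notes on a small set of amide-linked chain compounds tested in a functional assay on HCT-116 cells (Homo sapiens) for inhibition, read by colorimetric assay, with a stated time of 3 days; on this read-out higher numbers stand for weaker inhibition and lower numbers for stronger inhibition. Compound 1 `NC(=O)C(=O)NCCCCC(=O)Nc1ccccc1` reaches only the limit of this assay, > 100000 nM. That value for compound 1 is a limit, not a number. Compound 2 `O=C(CCCCCCNC(=O)C(O)(O)C(F)(F)F)Nc1nc2ccc(Br)cc2s1` gives 10300 nM in this assay. Compound 3 `COc1ccc2sc(NC(=O)CCCCCCNC(=O)C(O)(O)C(F)(F)F)nc2c1` gives 2180 nM in this assay. Of the two numbers shown, compound 2 is the higher one, and compound 3 sits below it by a gap beyond the usual scatter, so compound 2 is the weaker inhibitor of that pair. Within the data shown here, no two measured compounds differ in a single place, so no measured step is available; the only further point of evidence is the limit of > 100000 nM in this assay, at which 1 of the 3 values shown sits.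

Compound 4 `O=C(CCCCCCNC(=O)C(O)(O)C(F)(F)F)Nc1nc2ccc(Cl)cc2s1` is the unmeasured analogue of compound 2. The change is chloro in place of bromo on an aromatic carbon, with the remainder of the molecule untouched. Among the measured compounds shown here, none of the measured compounds bears on an exchange of this kind, so the step is expected to be small. The expected step is a 1.2-fold higher number from compound 2 to compound 4 (0.07 log units; within the scatter), that is, no change beyond the usual scatter in either direction. Compound 4 is therefore estimated at 12000 nM in this assay, within a range from 4000 nM to 35000 nM.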

Compound 4, half-maximal inhibitory concentration: 11000 nM
Estimate against measurement, compound 4: 1.1-fold (0.04 log units) above; the range from low to high includes it.
By their numbers in this assay, from the lowest: compound 3; then compounds 2 and 4 (each within the scatter of the next). At a limit, above all of these: compound 1.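

The series now has its first single-place step in this assay: chloro in place of bromo on an aromatic carbon gives a 1.1-fold higher number from compound 2 to compound 4 (0.03 log units; within the scatter). Among these compounds, at this place on the six-membered aromatic ring of the shared core, the two halogens therefore cannot be told apart on this read-out, and compound 2 and compound 4 stand as equals within the scatter, a reading the earlier compounds could not give since none of them differed in a single place. This holds for this one exchange and this one position only, and nothing shown gives a reason for the outcome.

Open, from the compounds shown here alone, is whether a group of another kind on the same aromatic carbon, such as an amine, a carboxylic acid or a nitrile, would give a step beyond the scatter in this assay, where a halogen exchange gives none. Equally open, going by these compounds, is how a fluoro at this place, or a longer chain on the same core with the halogen held fixed, would read in this assay.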